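Removing the N-aryl group from a pyrazoline scaffold

The source may report more compounds than this note shows. Statements on the series, on what has been measured and on what is new or still open speak of the compounds shown alone.

Of the compounds shown here, two sharing one core have been tested in a functional assay on HCT-116 cells (Homo sapiens) for cytotoxicity, read by crystal violet staining and colony formation, with a stated time of 7 days; on this read-out higher numbers stand for weaker inhibition and lower numbers for stronger inhibition. Compound 1 `COc1ccc(C2CC(c3c(O)ccc4ccccc34)=NN2c2ccc(Cl)cc2)cc1` gives 9800 nM, and compound 2 `COc1ccc(C2CC(c3c(O)ccc4ccccc34)=NN2c2ccc(Cl)cc2)c(OC)c1`, which carries an extra methoxy on an aromatic carbon, gives 5400 nM. Among the measured compounds shown here, the step of a 1.8-fold lower number from compound 1 to compound 2 (0.26 log units; within the scatter) is the only measured comparison, and it lies within the scatter, so compound 2 has the lowest of the two numbers without being separable from compound 1.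

Compound 3 `COc1ccc(C2CC(c3c(O)ccc4ccccc34)=NN2)c(OC)c1` differs from compound 2 by hydrogen in place of 4-chlorophenyl on an amine nitrogen in a ring. For the measured compounds named here, no measured step touches this position: the one comparison available concerns a methoxy on an aromatic carbon elsewhere in the molecule, and it was small. The expectation for compound 3 therefore rests on the structural change alone, a loss of a whole aromatic ring from the ring nitrogen, and it is estimated as a step of a 2.8-fold higher number from compound 2 to compound 3 (0.44 log units; beyond the scatter) toward a higher number in this assay, meaning weaker inhibition. Compound 3 is expected to give about 15000 nM, with a likely range from 4000 nM to 60000 nM.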

Compound 3, half-maximal inhibitory concentration: 2400 nM
Estimate against measurement, compound 3: 6.3-fold (0.80 log units) above; measured number below the stated range.
By their numbers in this assay, from the lowest: compound 3; then compounds 2 and 1 (each within the scatter of the next).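

In this assay the 4-chlorophenyl on the amine nitrogen in a ring proves dispensable for this cytotoxicity, since putting hydrogen in its place gives a 2.3-fold lower number from compound 2 to compound 3 (0.35 log units; beyond the scatter) and the number falls rather than rises. Among the compounds shown here, the step is modest, yet it is the first one in this small series to stand beyond the scatter, so this position can be told apart from noise in a way the methoxy change could not. Nothing available explains why removing this aromatic ring lowers the number.

From the compounds shown here alone, what remains open is whether the step comes from losing the chlorine or from losing the whole ring, which a plain phenyl on the same nitrogen would help to separate, while a small group such as methyl or acetyl there would show whether the nitrogen needs to keep its hydrogen. Going by these compounds, it is also open whether the same replacement gives a step of similar size on the core of compound 1, which lacks the extra methoxy.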